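Lengthening the amide chain of compound 1

The compounds below may be only part of what the source reports. "The series", "measured", "known", "first", "only" and "open" are said of these compounds alone.

In a functional assay (aorta) with Rattus norvegicus as the target (a lower number here means that less compound is needed, a higher number that more compound is needed for the effect), compound 1 `CNC(=O)C1=CC(C)(C)Oc2ccc([N+](=O)[O-])cc21` gives 10.7 nM. Going by the values given here, its only measured neighbour, compound 2 `CNC(=O)C1=CC(C)(CF)Oc2ccc([N+](=O)[O-])cc21`, gives 8.91 nM, so the two lie within the scatter of each other and neither can be ranked above the other. Among the compounds with values here, the single measured step is a 1.2-fold lower number from compound 1 to compound 2 (0.08 log units; within the scatter), and it places fluoro in place of hydrogen on a saturated chain carbon bound to a saturated ring carbon.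

Compound 3 `CC1(C)C=C(C(=O)NCCC#N)c2cc([N+](=O)[O-])ccc2O1` keeps the core of compound 1 but differs elsewhere: cyanomethyl in place of hydrogen on a saturated chain carbon bound to an amide-type nitrogen. Here cyanomethyl stands in place of hydrogen on a saturated chain carbon bound to an amide-type nitrogen, turning methylcarbamoyl into (2-cyanoethyl)carbamoyl. Within the data shown here, no measured compound varies this place, so the small step to compound 2 bears on it only weakly, and the data cannot fix the size or direction of the new step. A cautious guess leans towards a higher number in this assay, with the expected step being a 2.3-fold higher number from compound 1 to compound 3 (0.37 log units; beyond the scatter). For compound 3 the estimated value is 25 nM, with an expected range from 5 nM to 120 nM.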

Compound 3, half-maximal effective concentration: 2.82 nM
For compound 3 the middle estimate is 8.9-fold (0.95 log units) above the measured one; measured number outside the range, below it.
By their numbers in this assay, from the lowest: compound 3; then compounds 2 and 1 (each within the scatter of the next).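

Going by these compounds alone, the amide chain responds to change in this assay: here the step is a 3.8-fold lower number from compound 1 to compound 3 (0.58 log units; beyond the scatter), and it is the first step that lies beyond the scatter. Within the data shown here, the only earlier step, fluoro in place of hydrogen on a saturated chain carbon bound to a saturated ring carbon, is a 1.2-fold lower number from compound 1 to compound 2 (0.08 log units; within the scatter) and so could not show whether any part of the molecule mattered for this number. The new result shows that methylcarbamoyl can give way to the larger (2-cyanoethyl)carbamoyl, with its 3 additional heavy atoms and a triple bond, while less compound rather than more is needed for the effect, although nothing available explains why the number moves this way.

The compounds shown leave open whether the nitrile or simply the longer chain carries this step: a plain propyl chain would separate the two, and an amine or a carboxylic acid in place of the nitrile would show how much that group itself matters. Going by these compounds, it also remains open whether 2-cyanoethyl and the fluoro change of compound 2 would work together in a single molecule.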